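This account rests on a few compounds, and the source may have more. Where it says the series, first, only, none or still open, it means among the compounds named here.

Compound 1 `O=C(Nc1cccc(-c2ccco2)c1)C1CCCN(C(=O)c2cc(C(F)(F)F)cc(C(F)(F)F)c2)C1`: 0%
Compound 2 `O=C(Nc1cccc(Oc2ccccc2)c1)C1CCCN(C(=O)c2cccc(-c3ccco3)c2)C1`: 0%
Compound 3 `COC(=O)c1cccc(C(=O)N2CCCC(C(=O)Nc3ccc(Cl)cc3)C2)c1`: 0%

In an ADME assay on PC-3 cells (Homo sapiens) for cytotoxicity, read by WST assay, tested at 100 uM (on this read-out lower numbers stand for less inhibition and higher numbers for more inhibition at the one concentration tested (going by the name of the read-out)), compound 1 gives 0%, compound 2 gives 0% and compound 3 gives 0%. Compound 1 is thus level with both, and the nearest neighbour, compound 2, as well as the furthest, compound 3, sit within the scatter of it. No two of these compounds differ in only one place, so no single step is known. Compound 4 `Cc1nc(-c2cccc(NC(=O)C3CCCN(C(=O)c4cc(C(F)(F)F)cc(C(F)(F)F)c4)C3)c2)cs1` differs from compound 1 in one place: 2-methyl-1,3-thiazol-4-yl in place of furan-2-yl on an aromatic carbon; cut one bond further out, the change reads 3-(furan-2-yl)phenyl to 3-(2-methyl-1,3-thiazol-4-yl)phenyl. With every measured compound showing no inhibition, the expected step of a number 3 percentage points higher from compound 1 to compound 4 (within the scatter) is none beyond the scatter. Compound 4 is estimated at 3%, in the range 0% to 15%.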

Compound 4, a percentage reported as inhibition, at one concentration (the size of the read-out at that concentration, not a potency): 1%
For compound 4 the middle estimate is 2 percentage points above the measured one; low and high end bracket the measured number.
By their numbers in this assay, from the lowest: compounds 1, 2, 3 and 4 (each within the scatter of the next).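

In this assay, within the data shown here, the exchange of furan-2-yl for 2-methyl-1,3-thiazol-4-yl is the first single change that can be read, and it gives a number 1 percentage points higher from compound 1 to compound 4 (within the scatter) on this aromatic carbon. The position therefore carries a five-membered aromatic ring with 1 hetero atom or with 2 hetero atoms with no shift beyond the scatter. Nothing measured here bears on why this step is so small.

From the compounds shown here alone, whether an amine or a carboxylic acid on this aromatic carbon would shift the read-out stays open. So does whether any change elsewhere on the shared core would do so.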